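Swapping Chloro for Bromo on the Sulfonyl Ring

The source may hold more compounds than are shown below. What is called first, only, known or untested is meant among the compounds shown, and "the series" means these compounds.

Of the compounds shown here, three of a shared core have been tested. Compound 1 `O=C(/C=C/c1ccc(Cl)cc1)NS(=O)(=O)c1ccc(Br)cc1` and compound 2 `O=C(/C=C/c1ccc(Br)cc1)NS(=O)(=O)c1ccc(Br)cc1` carry a halogen on both rings, while compound 3 `O=C(/C=C/c1ccc([N+](=O)[O-])cc1)NS(=O)(=O)c1ccc(Cl)cc1` bears a nitro group on one ring and chloro on the other. In a functional assay on B16-F10 cells (Mus musculus) for antiproliferative activity, read by ELISA and MTT assay, with a stated time of 48 h (on this read-out higher numbers stand for weaker inhibition and lower numbers for stronger inhibition), compound 1 gives 2.8 ug/mL, compound 2 gives 5.1 ug/mL, and compound 3 gives 13.7 ug/mL.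

The change from compound 1 to compound 2 is bromo in place of chloro on an aromatic carbon, and it made a step of a 1.8-fold higher number from compound 1 to compound 2 (0.26 log units; within the scatter). Compound 3 gives the highest number of the three, and its values against compound 1 and compound 2 both lie beyond the usual scatter.

Compound 4 `O=C(/C=C/c1ccc([N+](=O)[O-])cc1)NS(=O)(=O)c1ccc(Br)cc1` is not yet measured. It differs from compound 3 by bromo in place of chloro on an aromatic carbon, the same change that turns compound 1 into compound 2, at the same place on the ring. The difference between the cores of compound 1 and compound 3 is not broken down here.

Because a 1.8-fold higher number from compound 1 to compound 2 (0.26 log units; within the scatter) was a small step, compound 4 is expected to give 18 ug/mL, with a likely range from 9 ug/mL to 40 ug/mL in this assay. For the measured compounds named here, that corresponds to an expected step of a 1.3-fold higher number from compound 3 to compound 4 (0.12 log units; within the scatter), resting on the one earlier instance of this change.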

Compound 4, half-maximal inhibitory concentration: 13.9 ug/mL
Estimate against measurement, compound 4: 1.3-fold (0.11 log units) above, and the stated range covers the measured number.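

In this assay, the change from 4-chlorophenyl to 4-bromophenyl gives a 1.0-fold higher number from compound 3 to compound 4 (0.01 log units; within the scatter), and this step does not differ from the earlier one on the other core: the same change on two cores in this assay, a 1.8-fold higher number (0.26 log units; within the scatter) from compound 1 to compound 2 and a 1.0-fold higher number (0.01 log units; within the scatter) from compound 3 to compound 4, 1.8-fold (0.25 log units) apart, within the scatter of two such steps Both steps are small, so on these two cores, chloro and bromo at this place cannot be told apart; this does not show that the same would hold on any other core, and two steps inside the scatter give no direction for the change. The larger steps come from the other substituted place, where nitro in place of bromo gives a 2.7-fold higher number from compound 2 to compound 4 (0.44 log units; beyond the scatter) and nitro in place of chloro gives a 5.0-fold higher number from compound 1 to compound 4 (0.70 log units; beyond the scatter), both beyond the scatter and both toward weaker inhibition.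

The compounds shown leave open how an amine or a carboxylic acid would compare with nitro and the halogens at either place, and whether fluoro in place of chloro would also be a small step. They also leave open whether swapping chloro for bromo stays this small on a core that carries one of those other groups.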